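The source may report more compounds than this note shows. Statements on the series, on what has been measured and on what is new or still open speak of the compounds shown alone.

Working notes on the series. For the measured compounds named here, compound 1 `COc1cccc(OC)c1C(=O)Nc1c[nH]nc1C(=O)NC1CC1` is one of two compounds measured in an ADME assay on MRC5 cells (Homo sapiens) for inhibition, with a stated time of 72 h; on this read-out higher numbers stand for an effect only at larger amounts of compound and lower numbers for an effect already at smaller amounts. In this assay compound 1 gives > 50000 nM, which is a limit of the assay and not a number. Its value sits at the limit of > 50000 nM in this assay, at which 1 of the 2 values shown sits, so compound 1 stands at the limit among the values shown, and its distance from the other measured compound cannot be fixed. Compound 2 `CO[C@H]1CC[C@H](NC(=O)c2n[nH]cc2NC(=O)c2ccc(F)cc2F)CC1` is the other measured compound; in this assay compound 2 gives 11000 nM. Going by the values given here, no measured pair differs in one place, so no measured step is available to guide the next change.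

Compound 3 `COCCNC(=O)c1n[nH]cc1NC(=O)c1c(OC)cccc1OC` differs from compound 1 in one place: 2-methoxyethyl in place of cyclopropyl on an amide-type nitrogen. The amide-type nitrogen keeps its carbonyl neighbour; only the group on it is exchanged. Among the compounds with values here, with compound 1 already at the limit and no measured step to lean on, the expected step is a number no higher from compound 1 to compound 3 (the limit leaves the size open), none beyond the scatter. Compound 3 is expected to give about 50000 nM in this assay, within 20000 nM to 120000 nM, with a fair chance that only a limit is reported again.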

Compound 3, half-maximal effective concentration: > 50000 nM
Compound 3: a limit, no number; the forecaster's own chance of this, stated with the estimate: 55%; the middle value lies on the limit itself.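

In this assay, for the compounds shown here, compound 1 and compound 3 both give a limit of the assay and not a number, and no step between them can be read because of where both values sit: the limit of > 50000 nM in this assay, at which 2 of the 3 values shown sit. The compounds shown leave open whether 2-methoxyethyl in place of cyclopropyl on an amide-type nitrogen shifts this read-out at all.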